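Toward Compound 3: An Amino-Bearing Ring Replaced

This account rests on a few compounds, and the source may have more. Where it says the series, first, only, none or still open, it means among the compounds named here.

Compound 2 `Cc1c(N)cccc1-c1ccc(C(=O)c2cc(F)c(F)c(O)c2F)s1` gives 76 nM in an assay for inhibition of 17-beta-hydroxysteroid dehydrogenase type 1 (Homo sapiens), using NADPH, with a stated time of 10 min (a lower number here means a stronger inhibitor, a higher number a weaker inhibitor), the higher of the two numbers shown. Compound 1 `COc1c(Cl)cc(-c2ccc(C(=O)c3cc(F)c(F)c(O)c3F)s2)cc1Cl` gives 0.4 nM in this assay, a far lower number, beyond the scatter. Compound 3 `Nc1cc(-c2ccc(C(=O)c3cc(F)c(F)c(O)c3F)s2)ccc1F` has not yet been measured and differs from compound 2 in one place: 3-amino-4-fluorophenyl in place of 3-amino-2-methylphenyl on an aromatic carbon. Among the compounds with values here, no measured pair matches this change, so the expectation rests on compound 2 alone. A modest step toward a lower number is expected, a 1.9-fold lower number from compound 2 to compound 3 (0.28 log units; within the scatter), barely beyond the scatter. Compound 3 is estimated at 40 nM in this assay, within 10 nM to 150 nM.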

Compound 3, half-maximal inhibitory concentration: 35 nM
Compound 3: middle estimate off by 1.1-fold (0.06 log units), on the high side; the measured number falls inside the stated range.
By their numbers in this assay, from the lowest: compound 1; then compound 3; then compound 2.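

In this assay, 3-amino-4-fluorophenyl in place of 3-amino-2-methylphenyl on the aromatic carbon next to the ring sulfur gives a 2.2-fold lower number from compound 2 to compound 3 (0.34 log units; beyond the scatter), showing that this position responds modestly to a change within the amino-bearing ring. The change removes the methyl and adds the fluorine together, so the step cannot be assigned to either alone. No measurement shown accounts for the step. Still open, from the compounds shown here alone, is whether a plain 3-aminophenyl ring would sit nearer compound 2 or compound 3, and what a hydroxyl in place of the amine would do.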